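The compounds below may be only part of what the source reports. "The series", "measured", "known", "first", "only" and "open" are said of these compounds alone.

Within the data shown here, compound 3 `O=C1C[C@H](OCc2cn(-c3ccc(Cl)cc3)nn2)[C@H]2CO[C@@H]1O2` is the only member of the series that returns a number in a functional assay on MDA-MB-231 cells (Homo sapiens) for cytotoxicity, read by MTT assay, with a stated time of 48 h (a lower number here means a stronger inhibitor, a higher number a weaker inhibitor), where compound 3 gives 26100 nM. Compound 1 `O=C1C[C@H](OCc2cn(Cc3ccccc3)nn2)[C@H]2CO[C@@H]1O2` reaches only the limit of this assay, giving > 50000 nM. Compound 2 `CCCCCCCCn1cc(CO[C@H]2CC(=O)[C@@H]3OC[C@H]2O3)nn1` likewise returns only a limit, > 50000 nM. The measured steps therefore lean on that limit of > 50000 nM in this assay, at which 2 of the 3 values shown sit: the step of an at least 1.9-fold lower number from compound 1 to compound 3 (0.28 log units; that floor lies within the scatter) and the step of an at least 1.9-fold lower number from compound 2 to compound 3 (0.28 log units; that floor lies within the scatter) each carry a floor that lies within the scatter, and the step that the two limits leave unreadable from compound 1 to compound 2 cannot be read at all.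

Compound 4 `O=C1C[C@H](OCc2cn(-c3ccccc3)nn2)[C@H]2CO[C@@H]1O2` differs from compound 3 by hydrogen in place of chloro on an aromatic carbon. Among the measured compounds shown here, none of the measured steps touches this position; all three exchange the whole group on the aromatic nitrogen, so the weight of the chloro substituent itself is untested. For the measured compounds named here, the only guidance is that compound 3 carries the 4-chlorophenyl group and alone yields a number, 26100 nM. Removing the chlorine is thus expected to cost rather than gain, though the size of that cost is not fixed by any shown step. The step of a 1.5-fold higher number from compound 3 to compound 4 (0.19 log units; within the scatter) is expected to run toward a weaker number. Compound 4 is estimated at 40000 nM, with a range from 15000 nM to 100000 nM, and a fair chance that only a limit is reported.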

Compound 4, half-maximal inhibitory concentration: 25200 nM
Compound 4: middle estimate off by 1.6-fold (0.20 log units), on the high side; the range from low to high includes it.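

In this assay, the chloro group is now tested on its own: a 1.0-fold lower number from compound 3 to compound 4 (0.02 log units; within the scatter), so hydrogen in place of chloro, para to a large group on the six-membered aromatic ring, gives no difference that can be read. Compound 3 and compound 4 cannot be told apart here, and in this pair the chlorine is not needed for a number to be returned. The steps of an at least 1.9-fold lower number from compound 2 to compound 4 (0.29 log units; that floor lies within the scatter) and an at least 1.9-fold lower number from compound 1 to compound 4 (0.29 log units; that floor lies within the scatter) are only floors, so the gap between phenyl and the octyl or benzyl groups on the aromatic nitrogen has no size yet: the limit of > 50000 nM in this assay, at which 2 of the 4 values shown sit.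

Going by these compounds, it remains open whether another group at the same place on the phenyl ring, such as methoxy, an amine or a carboxylic acid, would separate from chloro and hydrogen. Also open, on these data alone, is whether a change elsewhere, such as an alcohol in place of the carbonyl of the shared core, would shift the number at all.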